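A Second Chloro Group Tested for Cytotoxicity

The source may hold more compounds than are shown below. What is called first, only, known or untested is meant among the compounds shown, and "the series" means these compounds.

Compound 1, `O=C(/C=C/[C@H]1C[C@@H](O)[C@@H](O)C1)Nc1ccccc1`, and compound 2, `O=C(/C=C/[C@H]1C[C@@H](O)[C@@H](O)C1)Nc1ccc(Cl)cc1`, share one core and differ in a single chloro group. In an ADME assay on S2 cells (Drosophila melanogaster) for cytotoxicity, read by MTT assay (on this read-out higher numbers stand for an effect only at larger amounts of compound and lower numbers for an effect already at smaller amounts), compound 1 gives > 200000 nM, which is a limit of the assay rather than a measured number. In this assay compound 2 gives > 180000 nM, also a limit. The step that the two limits leave unreadable from compound 1 to compound 2 cannot be read because its two ends are the limits the limit of > 200000 nM in this assay, at which 1 of the 2 values shown sits, and (the limit of > 180000 nM in this assay, at which 1 of the 2 values shown sits); compound 2 therefore stands only at a limit on the numbers shown. Compound 3, `O=C(/C=C/[C@H]1C[C@@H](O)[C@@H](O)C1)Nc1ccc(Cl)c(Cl)c1`, carries the change (chloro in place of hydrogen on an aromatic carbon). For the measured compounds named here, the only measured step that bears on this change, a step that the two limits leave unreadable from compound 1 to compound 2, has no readable size, so no step beyond the scatter is expected in this assay from a further chloro group. Compound 3 is expected to give 200000 nM, within 70000 nM to 600000 nM, most likely again as a limit. The step expected here, a step that the limit leaves unreadable from compound 2 to compound 3, is essentially none.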

Compound 3, half-maximal effective concentration: > 160000 nM
Compound 3 ended at the assay's limit; the forecaster's own chance of this, stated with the estimate: 80%; the middle value lies beyond the limit too.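

Compound 2 and compound 3 both stand at limits in this assay, not at measured numbers, and the step between them cannot be read. The compounds shown leave open at what concentration any of them would affect these cells, and whether a chloro group changes that concentration at all.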